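The source may report more compounds than this note shows. Statements on the series, on what has been measured and on what is new or still open speak of the compounds shown alone.

Measured so far:
compound 1, `N/C(=N\NC(=S)N1CCCCCC1)c1ccccn1`: 62.2%
compound 2, `Cc1ccnc(/C(N)=N/NC(=S)N2CCN(c3ccccn3)CC2)c1`: 32.1%
compound 3, `N/C(=N\NC(=S)N1CCSCC1)c1ccccn1`: 54.3%

In a functional assay on MCF7 cells (Homo sapiens) for cytotoxicity, read by MTT assay, with a stated time of 72 h, tested at 10 uM (a lower number here means less inhibition of growth, a higher number more inhibition of growth at the concentration tested), compound 1 gives the highest of the three numbers. Compound 3 sits closest, within the scatter of compound 1, so the two cannot be ranked against each other. Compound 2 lies furthest away, beyond the scatter, and is the only one of the three that carries a methyl on its aromatic ring, though it also differs elsewhere.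

Compound 4, `Cc1ccnc(/C(N)=N/NC(=S)N2CCCCCC2)c1`, is compound 1 with one change: methyl in place of hydrogen on an aromatic carbon. Within the data shown here, no measured pair isolates this change. Compound 4 is expected to give a slightly lower number, with the step of a number 10.2 percentage points lower from compound 1 to compound 4 (beyond the scatter) likely still near the scatter. The estimate for compound 4 in this assay is 52%, ranging from 30% to 70%.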

Compound 4, percent growth inhibition at one concentration: 60.3%
Estimate against measurement, compound 4: 8.3 percentage points below; the measured number falls inside the stated range.
By their numbers in this assay, from the lowest: compound 2; then compounds 3, 4 and 1 (each within the scatter of the next).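

In this assay, the change of methyl in place of hydrogen on the aromatic carbon opposite the ring nitrogen gives a number 1.9 percentage points lower from compound 1 to compound 4 (within the scatter). Among these compounds, this is the first pair to isolate the change, and it shows that this position on the core of compound 1 accepts a methyl with no step that can be told from scatter. Nothing measured here offers an explanation for this result.

Still open, as far as these compounds go, is how an amine or a carboxylic acid at this position would behave, and whether methyl gives the same small step on the core of compound 3.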